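This account rests on a few compounds, and the source may have more. Where it says the series, first, only, none or still open, it means among the compounds named here.

Going by the values given here, compound 2 `CCCc1nc(C(C)(C)O)c(C(=O)OCOC(=O)C(C)(C)C)n1Cc1ccc(-c2ccccc2C(=O)O)cc1` gives 52% in a functional assay on the whole organism for inhibition, with Rattus norvegicus as the target, with a stated time of 1 h, at a dose of 1 mg/kg (a lower number here means less inhibition, a higher number more inhibition at the dose given (going by the name of the read-out)), the lower of the two numbers measured so far. Among the compounds with values here, its only neighbour, compound 1 `CCCc1nc(C(C)(C)O)c(C(=O)OCc2coc(=O)o2)n1Cc1ccc(-c2ccccc2C(=O)O)cc1`, gives 72% in this assay; the single step that separates them, a number 20 percentage points lower from compound 1 to compound 2 (beyond the scatter), is the one comparison that bears on what follows. Compound 3 `CCCc1nc(C(C)(C)O)c(C(=O)OC2OC(=O)c3ccccc32)n1Cc1ccc(-c2ccccc2C(=O)O)cc1` has not yet been measured. It differs from compound 2 in one place: a group of 10 heavy atoms (8 carbon, 2 oxygen; one five-membered non-aromatic ring with 1 hetero atom, one six-membered aromatic ring of carbon only) in place of a group of 8 heavy atoms (6 carbon, 2 oxygen; no ring), on an oxygen next to a carbonyl group. Both this change and the one already measured alter the group on an oxygen next to a carbonyl group, and the step already seen was modest though beyond the scatter. A shift of similar size, in either direction, is therefore the most the data support for compound 3, and the expected step from the measured neighbour is a number 8 percentage points higher from compound 2 to compound 3 (within the scatter). On this basis compound 3 is estimated at 60% in this assay, with a likely range from 40% to 78%.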

Compound 3, a percentage reported as inhibition, in the whole organism at one dose (the size of the read-out at that dose, not a potency): 73%
Beside the measured number, compound 3's estimate is 13 percentage points below it; measured number inside the range.
By their numbers in this assay, from the lowest: compound 2; then compounds 1 and 3 (each within the scatter of the next).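

On an oxygen next to a carbonyl group, the exchange of (((tert-butyl)carbonyl)oxy)methyl for the group carrying a five-membered non-aromatic ring and a six-membered aromatic ring of carbon only gives a number 21 percentage points higher from compound 2 to compound 3 (beyond the scatter) in this assay, so a change here can also raise the read-out, which the earlier step did not show. The two ring-bearing groups, though different in their rings, are separated only by a number 1 percentage points higher from compound 1 to compound 3 (within the scatter), so among these three compounds the two with a ring in this group stand together and compound 2, with no ring there, stands apart; none of the three goes against this. Nothing measured on these compounds accounts for this difference.

On these data alone, whether a longer chain in place of tert-butyl, or an amine within this group, would fall with compound 2 or with the ring-bearing pair remains open. So does how the carboxylic acid, with no group on this oxygen, would compare.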